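The source may report more compounds than this note shows. Statements on the series, on what has been measured and on what is new or still open speak of the compounds shown alone.

Three members of the series have been measured in a functional assay on MCF7 cells (Homo sapiens) for cytotoxicity, read by MTT assay, with a stated time of 24 h, tested at 32 ug/mL; a higher number here means a stronger effect of the compound at the concentration tested, a lower number a weaker effect. Compound 1 `Cn1c(-c2ccc(NC(=O)CSc3nc4cc(Cl)ccc4o3)cc2)nc(-c2ccccc2)c1-c1ccccc1` gives 59.7% and compound 2 `Cc1ccc2oc(SCC(=O)Nc3ccc(-c4nc(-c5ccccc5)c(-c5ccccc5)n4C)cc3)nc2c1` gives 57.7%; the step of a number 2 percentage points lower from compound 1 to compound 2 (within the scatter) is within the scatter. Compound 3 `Cn1nnnc1SCC(=O)Nc1ccc(-c2nc(-c3ccccc3)c(-c3ccccc3)n2C)cc1` gives 77.5%, the highest of the three numbers, with both other compounds beyond the scatter below it: the step of a number 17.8 percentage points higher from compound 1 to compound 3 (beyond the scatter) and the step of a number 19.8 percentage points higher from compound 2 to compound 3 (beyond the scatter).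

Compound 4 `Cn1c(-c2ccc(NC(=O)CSC3=NCCS3)cc2)nc(-c2ccccc2)c1-c1ccccc1` is not yet measured. It differs from compound 3 in one place: a group of 5 heavy atoms (3 carbon, 1 nitrogen, 1 sulfur; one five-membered non-aromatic ring with 2 hetero atoms) in place of a group of 6 heavy atoms (2 carbon, 4 nitrogen; one five-membered aromatic ring with 4 hetero atoms), on a sulfur

Among the compounds with values here, no measured step bears on this change directly. The two steps that touch the same position, a number 17.8 percentage points higher from compound 1 to compound 3 (beyond the scatter) and a number 19.8 percentage points higher from compound 2 to compound 3 (beyond the scatter), show that the 1-methyl-1H-tetrazol-5-yl on the sulfur gave the highest number of the set and that two other groups on that sulfur were each modestly lower. Within the data shown here, compound 4 now carries a third alternative at that position, so a modest fall from compound 3 toward the level of compound 1 and compound 2 is the expected outcome, with a wide margin because no pair of measured compounds shows this exact group.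

For compound 4 the estimate is 62%, within the range 45% to 80%, which corresponds to an expected step of a number 15.5 percentage points lower from compound 3 to compound 4 (beyond the scatter).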

Compound 4, a percentage reported as activity, at one concentration (the size of the read-out at that concentration, not a potency): 52.5%
Compound 4: the middle estimate sits 9.5 percentage points above what was measured, within the range that was stated.
By their numbers in this assay, from the lowest: compounds 4, 2 and 1 (each within the scatter of the next); then compound 3.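

Placing the five-membered non-aromatic ring with 2 hetero atoms on the sulfur in place of 1-methyl-1H-tetrazol-5-yl gives a number 25 percentage points lower from compound 3 to compound 4 (beyond the scatter) in this assay, so a third, structurally different group now stands beyond the scatter below the tetrazole compound. The steps of a number 5.2 percentage points lower from compound 2 to compound 4 (within the scatter) and a number 7.2 percentage points lower from compound 1 to compound 4 (within the scatter) show that this single non-aromatic ring is not separated from 5-methyl-1,3-benzoxazol-2-yl or 5-chloro-1,3-benzoxazol-2-yl, even though those groups are larger and carry a six-membered aromatic ring as well. Among the four compounds, only the 1-methyl-1H-tetrazol-5-yl group stands apart at this position, and no measurement is available to explain that separation.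

As far as these compounds go, it remains open whether the higher number belongs to the tetrazole itself or would also appear with another small aromatic ring on the sulfur, such as a triazole or an imidazole. The effect of the methyl on the tetrazole is also unresolved, as is whether the gaps seen at this single concentration would persist across a range of concentrations.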